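Methylsulfanyl in Place of Aminoamino: Forecasting Compound 4

A few compounds are considered here, and "the series" means these few. Any claim that something is new, unique, unknown or untested is made for them only; others in the source may bear on it.

Measured so far:
Compound 1, `COc1ccc(-c2nc(SC)n(C)c(=O)c2C#N)cc1`: 48 ug/mL
Compound 2, `COc1ccc(-c2nc(NN)n(C)c(=O)c2C#N)cc1`: 32 ug/mL
Compound 3, `COc1cccc(-c2nc(NN)n(C)c(=O)c2C#N)c1OC`: 36 ug/mL

These three compounds were tested in a functional assay, with a stated time of 10 min; a higher number here means a weaker inhibitor, a lower number a stronger inhibitor. From compound 2 to compound 1 the change is methylsulfanyl in place of aminoamino on an aromatic carbon, and the step observed is a 1.5-fold higher number from compound 2 to compound 1 (0.18 log units; within the scatter). The difference between the cores of compound 2 and compound 3 is not broken down here. Compound 4, `COc1cccc(-c2nc(SC)n(C)c(=O)c2C#N)c1OC`, is not yet measured; it arises from compound 3 by methylsulfanyl in place of aminoamino on an aromatic carbon. This is the same kind of change as the earlier one, but the surroundings differ: in compound 2 the place is meta to a group of 8 heavy atoms, in compound 3 meta to a large group.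

The step from compound 3 to compound 4 in this assay is expected to be a 1.5-fold higher number from compound 3 to compound 4 (0.18 log units; within the scatter), resting on the earlier step of a 1.5-fold higher number from compound 2 to compound 1 (0.18 log units; within the scatter). Because compound 3 gives 36 ug/mL, compound 4 is estimated at 54 ug/mL, expected between 30 ug/mL and 100 ug/mL.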

Compound 4, half-maximal inhibitory concentration: 43 ug/mL
Compound 4: middle estimate off by 1.3-fold (0.10 log units), on the high side, and the stated range covers the measured number.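

In this assay methylsulfanyl in place of aminoamino on an aromatic carbon gives a 1.2-fold higher number from compound 3 to compound 4 (0.08 log units; within the scatter) on the second core, and the change carries across the two cores with no difference that stands out from the scatter: the same change on two cores in this assay, a 1.5-fold higher number (0.18 log units; within the scatter) from compound 2 to compound 1 and a 1.2-fold higher number (0.08 log units; within the scatter) from compound 3 to compound 4, 1.3-fold (0.10 log units) apart, within the scatter of two such steps. Neither step lies beyond the scatter, so the swap has no demonstrated effect on either core in this assay. Two cores also cannot show that the change would behave alike across the wider series.

The compounds shown leave open what a simple amine, a longer alkylsulfanyl chain or a carboxylic acid would give on that aromatic carbon. They also leave open whether the step holds on cores other than these two.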